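Swapping the aryl group for a thiophene on the shared core

The compounds below may be only part of what the source reports. "The series", "measured", "known", "first", "only" and "open" are said of these compounds alone.

Compound 2 `COc1ccccc1-c1cn2ccnc2c(-c2ccc3ncn(C4CCCCC4)c3c2)n1` stands highest of the two numbers in a physicochemical assay for lipophilicity, using the shake flask method, in phosphate buffer, measured as octanol-water partition, with a stated time of 85 min, at pH 7.4 (a lower number here means a more polar compound, a higher number a more lipophilic compound), where compound 2 gives 1.72. Within the data shown here, its only neighbour, compound 1 `CCc1ccc(-c2cn3ccnc3c(-c3ccc4ncn(C5CCCCC5)c4c3)n2)cc1`, gives 1.66 in this assay, and the step of a number 0.06 log units higher from compound 1 to compound 2 (within the scatter) lies within the scatter. Compound 3 `c1csc(-c2cn3ccnc3c(-c3ccc4ncn(C5CCCCC5)c4c3)n2)c1` differs from compound 2 by one change: thiophen-2-yl in place of 2-methoxyphenyl on an aromatic carbon. Among the measured compounds shown here, only that one step bears on the new one, and it barely moved the number, so no shift beyond the scatter is expected for compound 3, with a number 0.17 log units lower from compound 2 to compound 3 (within the scatter). Compound 3 is therefore estimated at 1.55, in a range from 1.15 to 1.95.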

Compound 3, partition coefficient: 1.38
Compound 3: the middle estimate sits 0.17 log units above what was measured, and the stated range covers the measured number.
By their numbers in this assay, from the lowest: compounds 3, 1 and 2 (each within the scatter of the next, the first and the last beyond it).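

Thiophen-2-yl in place of 2-methoxyphenyl at this aromatic carbon gives the first step beyond the scatter in this assay: a number 0.34 log units lower from compound 2 to compound 3 (beyond the scatter), a modest change. The same thiophen-2-yl in place of 4-ethylphenyl stays inside the scatter, with a number 0.28 log units lower from compound 1 to compound 3 (within the scatter), so the size of the step depends on which aryl group leaves. Nothing available explains either step.

An amine or a carboxylic acid at this position remains untested in the compounds shown. So does whether a longer chain on the phenyl ring would shift the number.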